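The source may hold more compounds than are shown below. What is called first, only, known or untested is meant among the compounds shown, and "the series" means these compounds.

Among the measured compounds shown here, compound 1 `CCCN(C)c1ncnc2[nH]cc(-c3cccc(Cl)c3)c12` is the weaker of the two compounds measured so far: in an assay for inhibition of serine/threonine-protein kinase 3 (Homo sapiens), read by luminescence and ADP-Glo, in the presence of a further agent that is not named here (a lower number here means a stronger inhibitor, a higher number a weaker inhibitor), compound 1 gives 218 nM, while compound 2 `CC(CO)CN(C)c1ncnc2[nH]cc(-c3cccc(Cl)c3)c12` gives 58 nM, and the step of a 3.8-fold lower number from compound 1 to compound 2 (0.58 log units; beyond the scatter) is a modest gain. Compound 3 `Clc1cccc(-c2c[nH]c3ncnc(NCC4CC4)c23)c1` differs from compound 1 by (cyclopropylmethyl)amino in place of methyl(propyl)amino on an aromatic carbon. For the measured compounds named here, no measured step touches this change; the only measured step concerns a hydroxymethyl on the chain, so it offers no guide here. The expected step of a 1.5-fold lower number from compound 1 to compound 3 (0.16 log units; within the scatter) is therefore small, likely within the scatter, and compound 3 is estimated at 150 nM with a range of 50 nM to 450 nM.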

Compound 3, half-maximal inhibitory concentration: 213 nM
Compound 3: middle estimate off by 1.4-fold (0.15 log units), on the low side, within the range that was stated.
By their numbers in this assay, from the lowest: compound 2; then compounds 3 and 1 (each within the scatter of the next).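

In this assay, putting (cyclopropylmethyl)amino in place of methyl(propyl)amino on this aromatic carbon gives a 1.0-fold lower number from compound 1 to compound 3 (0.01 log units; within the scatter), so adding a three-membered ring and a hydrogen-bond donor leaves the number within the scatter. The hydroxymethyl-bearing group keeps its advantage over (cyclopropylmethyl)amino, with a 3.7-fold higher number from compound 2 to compound 3 (0.56 log units; beyond the scatter). No measurement here offers an explanation for either result.

The compounds shown do not separate the effect of the ring from that of the nitrogen hydrogen. Going by these compounds, it also remains open how an aminomethyl group in place of the hydroxymethyl, or a longer chain carrying it, would read.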